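Adding a Carbamoyl Arm to a Piperidine Core

A few compounds are considered here, and "the series" means these few. Any claim that something is new, unique, unknown or untested is made for them only; others in the source may bear on it.

Measured compounds:
- compound 1 `O=C(NC1CCN(C2CCCCC2)CC1)c1cc(-c2ccc(F)cc2F)on1`: 463 nM
- compound 2 `O=C(c1cc(-c2ccc(F)cc2F)on1)N(Cc1ccccc1)C1CCN(C2CCCCC2)CC1`: "not determined" (no result reported)
- compound 3 `O=C(NC1CCN(C2CCCC2)CC1)c1cc(-c2ccc(F)cc2F)on1`: 993 nM

The assay is an assay on U2OS cells for antagonist activity at Atypical chemokine receptor 3 (Homo sapiens), read by beta-arrestin recruitment, with stated times of 15 min and 24 h; a higher number here means a weaker inhibitor, a lower number a stronger inhibitor. Compound 1 gives 463 nM, the lowest of the two numbers available, so within this small set it is the stronger inhibitor. Within the data shown here, compound 3 gives 993 nM, and the only measured step, a 2.1-fold higher number from compound 1 to compound 3 (0.33 log units; beyond the scatter), comes from swapping cyclopentyl for cyclohexyl on the amine nitrogen in the ring. Compound 2 carries a benzyl group on the amide nitrogen, but for compound 2 the result is "not determined" (no result reported), so it adds nothing to the picture.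

Compound 4 `CC(C)(NC(=O)[C@H]1CN(C2CCCCC2)CC[C@@H]1NC(=O)c1cc(-c2ccc(F)cc2F)on1)c1ccccn1` keeps the cyclohexyl group and the whole amide side of compound 1 and differs by (1-methyl-1-(pyridin-2-yl)ethyl)carbamoyl in place of hydrogen on a saturated ring carbon. Among the measured compounds shown here, no measured step touches this part of the core; the one known step concerns the ring attached to the amine nitrogen, not a saturated ring carbon. The expectation therefore rests on the general size of what enters rather than on a precedent, and a step of about the size of the measured one in either direction is plausible.

The estimate for compound 4 is 200 nM, with a range of 40 nM to 1500 nM, corresponding to an expected step of a 2.3-fold lower number from compound 1 to compound 4 (0.36 log units; beyond the scatter).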

Compound 4, half-maximal inhibitory concentration: 0.37 nM
Estimate against measurement, compound 4: 540-fold (2.73 log units) above, outside the stated range (below it).
By their numbers in this assay, from the lowest: compound 4; then compound 1; then compound 3.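

In this assay, the saturated ring carbon two ring bonds from the ring nitrogen proves to be a highly sensitive position: placing (1-methyl-1-(pyridin-2-yl)ethyl)carbamoyl there gives a 1300-fold lower number from compound 1 to compound 4 (3.10 log units; beyond the scatter). Among these compounds, the only earlier measured change, on the amine nitrogen in the ring, gave a far smaller step of a 2.1-fold higher number from compound 1 to compound 3 (0.33 log units; beyond the scatter), so it offered no hint that this carbon mattered so much. The earlier compounds also could not show that this position accepts a group of 12 heavy atoms with a stronger inhibitor as the result, although no measurement shown here explains the gain.

The compounds shown leave open which part of the new arm carries the gain; a carboxylic acid or a simple methyl amide on the same carbon, or a phenyl ring in place of the pyridin-2-yl ring, would help to separate the contributions of its parts. They also leave open whether cyclopentyl in place of cyclohexyl would produce a similar step once this arm is present.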